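The compounds below may be only part of what the source reports. "The series", "measured", "known", "first", "only" and "open" are said of these compounds alone.

Going by the values given here, compound 1 `CNC(=O)N1CCCc2ccc(NC(=O)c3cccc(-c4ccccc4)c3)cc21` is one of three compounds measured in a functional assay on MV4-11 cells (Homo sapiens) for antiproliferative activity, with a stated time of 6 days, tested at 6.25 uM (on this read-out higher numbers stand for a stronger effect at the one concentration tested and lower numbers for a weaker effect), where compound 1 gives 1.39%, the lowest of the three. Compound 2 `CNC(=O)N1CCCc2ccc(NC(=O)c3ccc(-c4ccncc4)cc3)cc21` gives 88.7% in this assay, and compound 3 `CNC(=O)N1CCCc2ccc(NC(=O)c3ccc(-c4cnn(S(C)(=O)=O)c4)cc3)cc21` gives 40.2%. Compound 4 `CNC(=O)N1CCCc2ccc(NC(=O)c3cccc(-c4cnn(S(C)(=O)=O)c4)c3)cc21` is not yet measured; it differs from compound 1 by 1-(methylsulfonyl)-1H-pyrazol-4-yl in place of phenyl on an aromatic carbon. Among the compounds with values here, the one measured step that bears on this, a number 48.5 percentage points lower from compound 2 to compound 3 (beyond the scatter), replaces a different group and sits at another position, so it gives only indirect guidance. Compound 3, which carries the same entering group, stands well above compound 1, so a moderate rise is expected, as a number 13.6 percentage points higher from compound 1 to compound 4 (beyond the scatter). For compound 4 the estimate in this assay is 15%, within a range from 0% to 45%.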

Compound 4, a percentage reported as inhibition, at one concentration (the size of the read-out at that concentration, not a potency): 18%
The estimate for compound 4 lay 3 percentage points below the measured number; the range from low to high includes it.
By their numbers in this assay, from the lowest: compound 1; then compound 4; then compound 3; then compound 2.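

Putting 1-(methylsulfonyl)-1H-pyrazol-4-yl in place of phenyl, on the aromatic carbon meta to a large group, gives a number 16.6 percentage points higher from compound 1 to compound 4 (beyond the scatter) in this assay. Going by these compounds alone, this is the first measured step at this position, and it shows that the number here does respond to the group attached, though only modestly. No measurement shown explains this rise.

From the compounds shown here alone, it remains open how pyridin-4-yl would behave at this position. Going by these compounds, it is also open whether a smaller group, such as an amine or a carboxylic acid, would raise or lower the number.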